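The compounds below may be only part of what the source reports. "The series", "measured", "known", "first", "only" and "open" are said of these compounds alone.

Three compounds sharing one core have been compared in a functional assay (Nicotiana tabacum); a lower number here means a stronger inhibitor, a higher number a weaker inhibitor. Compound 1 `CSc1nc(NC2CCCC2)c2cccnc2n1` gives 490 nM, compound 2 `CSc1nc(NCC(C)C)c2cccnc2n1` gives 540 nM, and compound 3 `CSc1nc(Nc2ccccc2)c2cccnc2n1` gives 15900 nM, the highest number of the three. The large steps of a 32-fold higher number from compound 1 to compound 3 (1.51 log units; beyond the scatter) and a 29-fold higher number from compound 2 to compound 3 (1.47 log units; beyond the scatter) both arise from replacing an aliphatic group with phenyl on a nitrogen on an aromatic ring. Compound 4 `CSc1nc(Nc2ccc(C#N)cc2)c2cccnc2n1` differs from compound 3 by cyano in place of hydrogen on an aromatic carbon. Among the compounds with values here, no measured step alters the phenyl ring itself, so none bears directly on this change, and no step beyond the scatter is expected. The expected step is no change at the digits printed from compound 3 to compound 4 (within the scatter). Compound 4 is therefore estimated to give 15900 nM, within a range of 5000 nM to 50000 nM.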

Compound 4, half-maximal inhibitory concentration: 7560 nM
Beside the measured number, compound 4's estimate is 2.1-fold (0.32 log units) above it; the measured number falls inside the stated range.
By their numbers in this assay, from the lowest: compounds 1 and 2 (each within the scatter of the next); then compound 4; then compound 3.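

In this assay the phenyl ring on the nitrogen responds to a change of its own: cyano in place of hydrogen, para to a large group, gives a 2.1-fold lower number from compound 3 to compound 4 (0.32 log units; beyond the scatter) and so a modest step beyond the scatter. Within the data shown here, earlier steps only exchanged the whole group on the nitrogen, so this is the first reading from the ring itself. Nothing shown explains the step.

As far as these compounds go, whether a chlorine atom, a methoxy group or a carboxylic acid at this position would move the number the same way remains open.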